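This account rests on a few compounds, and the source may have more. Where it says the series, first, only, none or still open, it means among the compounds named here.

Compound 3 `NCc1ccc(C(=O)Nc2cccc(NC(=O)COc3ccc4c(=O)ccoc4c3)c2)cc1` stands highest of the three measured compounds in an assay on isolated protein for inhibition of Rho-associated protein kinase 1 (Homo sapiens), read by scintillation counting, radiometric assay and 33P incorporation, with a stated time of 40 min, in the presence of a further agent that is not named here; on this read-out lower numbers stand for stronger inhibition and higher numbers for weaker inhibition: compound 3 gives 532 nM. Compound 1 `CCc1ccc(C(=O)Nc2cccc(NC(=O)COc3ccc4c(=O)ccoc4c3)c2)cc1` gives 235 nM, and compound 2 `CC(C)(C)c1cc(C(=O)Nc2cccc(NC(=O)COc3ccc4c(=O)ccoc4c3)c2)no1` gives 101 nM. The two steps that reach compound 3 were a 2.3-fold higher number from compound 1 to compound 3 (0.35 log units; beyond the scatter) and a 5.3-fold higher number from compound 2 to compound 3 (0.72 log units; beyond the scatter). Compound 4 `Nc1ccc(C(=O)Nc2cccc(NC(=O)COc3ccc4c(=O)ccoc4c3)c2)cc1` differs from compound 3 by amino in place of aminomethyl on an aromatic carbon. Among the measured compounds shown here, no measured step removes a chain carbon in this way, so the bearing of the known steps is indirect; the nearest guide is that an amino on the chain end already cost a modest amount, and that cost seems likely to remain. The number for compound 4 is therefore expected to stay close to that of compound 3, with a 1.1-fold lower number from compound 3 to compound 4 (0.03 log units; within the scatter) within the scatter, estimated at 500 nM in a range of 200 nM to 1300 nM.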

Compound 4, half-maximal inhibitory concentration: 802 nM
Compound 4: the middle estimate sits 1.6-fold (0.21 log units) below what was measured; measured number inside the range.
By their numbers in this assay, from the lowest: compound 2; then compound 1; then compounds 3 and 4 (each within the scatter of the next).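

In this assay, taking out the chain carbon between the ring and the amine gives a 1.5-fold higher number from compound 3 to compound 4 (0.18 log units; within the scatter) and so no change that can be told from scatter. The amino group directly on the ring also stays on the weaker side of the series, with a 3.4-fold higher number from compound 1 to compound 4 (0.53 log units; beyond the scatter) and a 7.9-fold higher number from compound 2 to compound 4 (0.90 log units; beyond the scatter) as its gaps to the two compounds without an amine. No evidence here explains these numbers. Still open, going by these compounds, is whether a longer chain such as 2-aminoethyl, or a hydroxyl or methoxy group in the same place, would fall with the two amines or with ethyl.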